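Working notes: fluoro for methyl in the series

The compounds below may be only part of what the source reports. "The series", "measured", "known", "first", "only" and "open" are said of these compounds alone.

compound 1 `COc1ccc(C(=O)N2CCN(CC(=O)N3CCN(CCCc4c[nH]c5ccccc45)CC3)CC2)cc1`: 148000 nM
compound 2 `Cc1ccc(C(=O)N2CCN(CC(=O)N3CCN(CCCc4c[nH]c5ccccc45)CC3)CC2)cc1`: > 200000 nM (a limit)

In an ADME assay on SH-SY5Y cells (Homo sapiens) for cytotoxicity, read by MTT assay, with a stated time of 72 h (on this read-out higher numbers stand for weaker inhibition and lower numbers for stronger inhibition), compound 1 gives 148000 nM as a measured number. Compound 2 gives > 200000 nM as a limit of the assay and not a number; it stands at the limit of > 200000 nM in this assay, at which 1 of the 2 values shown sits, and has no exact place.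

Compound 3 `O=C(CN1CCN(C(=O)c2ccc(F)cc2)CC1)N1CCN(CCCc2c[nH]c3ccccc23)CC1` comes from compound 2 by one change: fluoro in place of methyl on an aromatic carbon (fluoro in place of methyl on an aromatic carbon, para to a large group). Among the measured compounds shown here, the only measured step is an at least 1.3-fold higher number from compound 1 to compound 2 (0.13 log units; that floor lies within the scatter) and it also exchanges a group on an aromatic carbon. Its floor shows no size beyond the scatter, so no large shift is expected. The expected step in this assay is an at least 1.1-fold lower number from compound 2 to compound 3 (0.07 log units; that floor lies within the scatter) and no clear direction beyond the scatter is expected. Compound 3 is estimated at 170000 nM with an expected range from 100000 nM to 250000 nM in this read-out.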

Compound 3, half-maximal inhibitory concentration: 188000 nM
The estimate for compound 3 lay 1.1-fold (0.04 log units) below the measured number, and the stated range covers the measured number.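

With fluoro on this aromatic carbon, para to a large group, compound 3 gives a measured number in this assay and not a limit, so this position now has exact numbers for two groups, methoxy and fluoro. The exchange between them gives a 1.3-fold higher number from compound 1 to compound 3 (0.10 log units; within the scatter) and so shows no separation between the two groups in this assay at this position. Compound 2 holds a limit and not a number, so the change from methyl to fluoro reads only as a floor, an at least 1.0-fold lower number from compound 2 to compound 3 (0.02 log units; that floor lies within the scatter) and its true size stays unknown: the limit of > 200000 nM in this assay, at which 1 of the 3 values shown sits.

From the compounds shown here alone, whether any group at this position moves the number beyond the scatter remains open, for instance an amine or a carboxylic acid. Also open, going by these compounds, is whether the exact place of compound 2 differs from that of compound 3 at all.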